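Working notes: fluoro in place of methoxy

The compounds below may be only part of what the source reports. "The series", "measured", "known", "first", "only" and "open" are said of these compounds alone.

compound 1 `COc1cc(-c2ccnc3cc(-c4ccc(Cl)cc4)nn23)cc(OC)c1OC` — 1490 nM
compound 2 `COc1ccc(-c2cc3nccc(-c4cc(OC)c(OC)c(OC)c4)n3n2)cc1` — 373 nM

In a functional assay on HeLa cells (Homo sapiens) for inhibition, read by CCK-8 assay, with a stated time of 48 h (a higher number here means a weaker inhibitor, a lower number a stronger inhibitor), compound 2 holds the lowest of the two numbers shown. For the measured compounds named here, the only other measured compound is compound 1, and the single measured step is a 4.0-fold lower number from compound 1 to compound 2 (0.60 log units; beyond the scatter). Compound 3 `COc1cc(-c2ccnc3cc(-c4ccc(F)cc4)nn23)cc(OC)c1OC` differs from compound 2 by fluoro in place of methoxy on an aromatic carbon. Going by the values given here, the only step that bears on this is a 4.0-fold lower number from compound 1 to compound 2 (0.60 log units; beyond the scatter), which runs the other way, from chloro to methoxy; here methoxy leaves and fluoro enters, so an upward step is expected, with fluoro not chloro and its size uncertain. The expected step is a 2.7-fold higher number from compound 2 to compound 3 (0.43 log units; beyond the scatter). Compound 3 is estimated at 1000 nM, within 400 nM to 2500 nM.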

Compound 3, half-maximal inhibitory concentration: 5840 nM
Compound 3: middle estimate off by 5.8-fold (0.77 log units), on the low side, and the stated range ends below it.
By their numbers in this assay, from the lowest: compound 2; then compound 1; then compound 3.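

Replacing 4-methoxyphenyl with 4-fluorophenyl matters far more at this position than the earlier step indicated, with a 16-fold higher number from compound 2 to compound 3 (1.19 log units; beyond the scatter) as the large change. The two halogens are not interchangeable here either, with a 3.9-fold higher number from compound 1 to compound 3 (0.59 log units; beyond the scatter) as a further change, so methoxy, chloro and fluoro rank in that order from lowest number to highest. Nothing at hand accounts for this order.

Still open, going by these compounds, is where other groups at this place would fall, such as an amine, a hydroxyl or an ethoxy group.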